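From 3-Bromophenyl to 2,3,4-Trimethoxyphenyl on a Shared Core

A few compounds are considered here, and "the series" means these few. Any claim that something is new, unique, unknown or untested is made for them only; others in the source may bear on it.

In a functional assay on MCF7 cells (Homo sapiens) for cytotoxicity, read by MTT assay, with a stated time of 72 h (on this read-out lower numbers stand for stronger inhibition and higher numbers for weaker inhibition), compound 1 (`O=C(N/N=C/c1cccc(Br)c1)Nc1cc2c(Nc3ccc(F)c(Cl)c3)ncnc2cc1O[C@H]1CCOC1`) gives 12400 nM as its result. Compound 3 (`COc1cc2ncnc(Nc3ccc(F)c(Cl)c3)c2cc1NC(=O)N/N=C/c1cccc(Br)c1`) gives 27100 nM and so holds the higher of the two numbers. Compound 2 (`O=C(N/N=C/c1cccc(Cl)c1Cl)Nc1cc2c(Nc3ccc(F)c(Cl)c3)ncnc2cc1O[C@H]1CCOC1`) reads "not active" (no number reported) with no number, so a loss of activity cannot be ruled out. Compound 4 (`COc1cc2ncnc(Nc3ccc(F)c(Cl)c3)c2cc1NC(=O)N/N=C/c1ccc(OC)c(OC)c1OC`) has 2,3,4-trimethoxyphenyl in place of 3-bromophenyl on a carbon with a double bond to nitrogen. Among the compounds with values here, the one measured step, a 2.2-fold higher number from compound 1 to compound 3 (0.34 log units; beyond the scatter) for a change elsewhere, is modest and offers no direct guide. The expected step is small, a 1.2-fold higher number from compound 3 to compound 4 (0.07 log units; within the scatter) with no firm direction. In this assay compound 4 is estimated at 32000 nM with 11000 nM to 90000 nM as its range.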

Compound 4, half-maximal inhibitory concentration: "not active" (no number reported)
Nothing numeric was reported for compound 4, so the estimate cannot be set against anything.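

Within the data shown here, compound 4 reads "not active" with no number, so no step from compound 3 to compound 4 can be read. Going by these compounds, how far 2,3,4-trimethoxyphenyl shifts activity relative to 3-bromophenyl stays open. No supporting data bear on this result.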